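Changing the ring on a long-chain amide

The source may report more compounds than this note shows. Statements on the series, on what has been measured and on what is new or still open speak of the compounds shown alone.

compound 1 `CCCCCCCCCCCC[C@@H](O)[C@H]1CC[C@H]([C@H](O)CCCCCCCCCCNC(=O)c2ccco2)O1` gives 100000 nM
compound 2 `CCCCCCCCCCCC[C@@H](O)[C@H]1CC[C@H]([C@H](O)CCCCCCCCCCNC(=O)c2ccsc2)O1` gives 2190 nM

Among the compounds with values here, in a functional assay on DU-145 cells (Homo sapiens) for inhibition, read by colorimetric assay and sulforhodamine B assay, with a stated time of 48 h (a higher number here means a weaker inhibitor of growth, a lower number a stronger inhibitor of growth), compound 2 holds the lower of the two numbers so far. Within the data shown here, the only measured step is large: a 46-fold lower number from compound 1 to compound 2 (1.66 log units; beyond the scatter), with thiophen-3-yl in place of furan-2-yl on a carbonyl carbon.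

Compound 3 `CCCCCCCCCCCC[C@@H](O)[C@H]1CC[C@H]([C@H](O)CCCCCCCCCCNC(=O)c2ccnn2C)O1` is still unmeasured. It carries 1-methyl-1H-pyrazol-5-yl in place of thiophen-3-yl on a carbonyl carbon. Among the measured compounds shown here, this again exchanges one five-membered aromatic ring for another, and the single earlier exchange shows that such a swap can matter, though it says nothing directly about this new group. Compound 2 at 2190 nM is the better of only two results, so a higher number is the likelier outcome. The expected change is a 5.5-fold higher number from compound 2 to compound 3 (0.74 log units; beyond the scatter), clearly beyond the scatter but uncertain in size. Compound 3 is estimated at 12000 nM (expected range 2500 nM to 60000 nM) in this assay for now.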

Compound 3, concentration for 50% growth inhibition: 100000 nM
Estimate against measurement, compound 3: 8.3-fold (0.92 log units) below; the measured number lies above the stated range.
By their numbers in this assay, from the lowest: compound 2; then compounds 1 and 3 (each within the scatter of the next).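

In this assay the thiophen-3-yl group turns out to be the exception among the three rings on this carbonyl carbon: putting 1-methyl-1H-pyrazol-5-yl in its place gives a 46-fold higher number from compound 2 to compound 3 (1.66 log units; beyond the scatter) and loses the whole gain seen earlier. Measured against the furan-2-yl group, the same 1-methyl-1H-pyrazol-5-yl group gives no change at the digits printed from compound 1 to compound 3 (within the scatter), so two different rings now share one number and only the thiophen-3-yl compound stands apart. Nothing available here explains why these rings differ.

From the compounds shown here alone, it remains open whether the sulfur-containing ring itself matters or whether other rings at this place would do as well. A thiophen-2-yl group or a phenyl ring on the same carbonyl carbon would test this.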